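The compounds below may be only part of what the source reports. "The series", "measured", "known", "first", "only" and "open" are said of these compounds alone.

In a functional assay on the whole organism (Tail, strain ICR) with Mus musculus as the target, in the tail flick test, with a stated time of 60 min, at a dose of 25 umol/kg by the oral route (a higher number here means a stronger effect of the compound at the dose given, a lower number a weaker effect), the three measured compounds give the following numbers:

Compound 1, `N=C(N)NCCC[C@H](NC(=O)CN(c1nc(Cl)nc2[nH]cnc12)C1CC1)C(=O)OCc1ccccc1`: 30.6%
Compound 2, `N=C(N)NCCC[C@H](NC(=O)CN(c1ncnc2c1ncn2C1CCCCO1)C1CC1)C(=O)OCc1ccccc1`: 52.4%
Compound 3, `CC(C)C[C@H](NC(=O)CN(c1nc(Cl)nc2[nH]cnc12)C1CC1)C(=O)OCc1ccccc1`: 27.3%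

Compound 2 stands highest of the three in this assay, with compound 1 nearest and compound 3 furthest, both beyond the scatter. Compound 1 and compound 2 carry different cores; how these two cores differ is not broken down here.

Compound 3 is compound 1 with one change: a group of 3 heavy atoms (3 carbon; no ring) in place of a group of 6 heavy atoms (3 carbon, 3 nitrogen; no ring), on a saturated chain carbon, two bonds along the chain from an amide-type nitrogen and a carbonyl carbon. This change gave a number 3.3 percentage points lower from compound 1 to compound 3 (within the scatter), so the two compounds cannot be told apart in this assay.

Compound 4, `CC(C)C[C@H](NC(=O)CN(c1ncnc2c1ncn2C1CCCCO1)C1CC1)C(=O)OCc1ccccc1`, is not yet measured. It is compound 2 with the same change made once more: a group of 3 heavy atoms (3 carbon; no ring) in place of a group of 6 heavy atoms (3 carbon, 3 nitrogen; no ring), on a saturated chain carbon, two bonds along the chain from an amide-type nitrogen and a carbonyl carbon. The place is the same as in the first pair.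

Because the first pair showed a number 3.3 percentage points lower from compound 1 to compound 3 (within the scatter), a step of similar, small size is expected from compound 2 to compound 4, estimated as a number 4.4 percentage points lower from compound 2 to compound 4 (within the scatter), while a different core may make the outcome less sure. Compound 4 is therefore expected to give about 48% in this assay, most likely between 30% and 64%.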

Compound 4, a percentage reported as activity, at one dose (the size of the read-out at that dose, not a potency): 34.2%
Compound 4: middle estimate off by 13.8 percentage points, on the high side; the measured number falls inside the stated range.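

In this assay, putting isopropyl in place of the group of 6 heavy atoms on the core of compound 2 gave a number 18.2 percentage points lower from compound 2 to compound 4 (beyond the scatter), so on this core the change has a clear effect at the dose given. Set beside the earlier pair, the change does not carry over from one core to the other with the same size: the same change on two cores in this assay, a number 3.3 percentage points lower (within the scatter) from compound 1 to compound 3 and a number 18.2 percentage points lower (beyond the scatter) from compound 2 to compound 4, 14.9 percentage points apart, beyond the scatter of two such steps This shows that the size of the step depended on the core in these two pairs, but two pairs give no rule for other cores and do not show which feature of the cores lies behind the gap.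

The compounds shown leave open how other groups on this saturated chain carbon, such as a simple amine, a carboxylic acid or a longer chain, would behave on each of the two cores. They also leave open whether the gap between the two steps would hold at other doses or at other times.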